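The source may hold more compounds than are shown below. What is called first, only, known or untested is meant among the compounds shown, and "the series" means these compounds.

Measured in a functional assay on MDA-MB-435 cells (Homo sapiens) for cytotoxicity, read by MTT assay, with a stated time of 72 h; on this read-out lower numbers stand for stronger inhibition and higher numbers for weaker inhibition:
compound 1 `NCCCNc1c(C(=O)NCc2ccc(F)cc2)nc(Br)c2cccnc12`: 5000 nM.
compound 2 `CC(C)(C)OC(=O)N1CCN(c2c(C(=O)NCc3ccc(F)cc3)nc(Br)c3cccnc23)CC1`: 10000 nM.
compound 3 `O=C(NCCCNc1c(C(=O)NCc2ccc(F)cc2)nc(Br)c2cccnc12)c1ccccc1`: > 20000 nM, a limit of the assay.

Compound 1 sits at the low end of these numbers together with compound 2, the two lying within the usual scatter of each other. Compound 4 `C[C@H](Nc1c(C(=O)NCc2ccc(F)cc2)nc(Br)c2cccnc12)c1ccccc1` keeps the core of compound 1 and makes one change, 1-phenylethyl in place of 3-aminopropyl on a nitrogen on an aromatic ring. For the measured compounds named here, one measured step bears on this, loosely: an at least 4.0-fold higher number from compound 1 to compound 3 (0.60 log units; beyond the scatter), with benzoyl in place of hydrogen on an amine nitrogen. Like compound 4, compound 3 no longer carries the free amine of compound 1. Going by that step, a modest move to a higher number, meaning weaker inhibition, is expected in this assay: a 2.4-fold higher number from compound 1 to compound 4 (0.38 log units; beyond the scatter). The estimated value for compound 4 is 12000 nM, with an expected range of 4000 nM to 30000 nM.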

Compound 4, half-maximal inhibitory concentration: > 20000 nM
Compound 4 gave a limit, no number; the forecaster's own chance of this, stated with the estimate: 30%; at least 1.6-fold (0.22 log units) between middle value and limit.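

Compound 3 keeps the 3-aminopropyl chain and only caps its amine, whereas compound 4 shows what happens when the whole chain on this nitrogen is exchanged: 1-phenylethyl brings an at least 4.0-fold higher number from compound 1 to compound 4 (0.60 log units; beyond the scatter), which means weaker inhibition. So a ring-bearing group without the amine does not hold the activity of compound 1 here. The size of this step remains unknown, since the result for compound 4 is a limit and not a number: the limit of > 20000 nM in this assay, at which 2 of the 4 values shown sit.

Open, as far as these compounds go, is whether a longer chain ending in an amine would do better or worse than 3-aminopropyl. Also open, from the compounds shown here alone, is what a carboxylic acid at the end of the chain would do.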